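The source may hold more compounds than are shown below. What is called first, only, known or untested is meant among the compounds shown, and "the series" means these compounds.

Measured compounds:
- compound 1, `COc1ccc(-c2ccc(-c3ccc(C(=N)N)o3)o2)cc1`: 8.1%
- compound 2, `N=C(N)c1ccc(-c2ccc(-c3cncc4ccccc34)s2)s1`: "non-toxic" (no number reported)

In an ADME assay on cells (Erythrocyte, Homo sapiens) for activation, read by hemolysis, with a stated time of 30 min, tested at 2.5 mM (a lower number here means a weaker effect, a higher number a stronger effect of the compound at the concentration tested), compound 1 gives 8.1%. Within the data shown here, compound 1 holds the only number reported in this assay; for compound 2 this assay gives "non-toxic" (no number reported), without a number, so no ordering between the two can be drawn beyond what those two entries show.

Compound 3, `N=C(N)c1ccc(-c2ccc(-c3ccccc3)o2)o1`, has not been measured in this assay. It differs from compound 1 in one place: hydrogen in place of methoxy on an aromatic carbon. Among the measured compounds shown here, with no step between two measured compounds available, the size of the change can only be guessed. Given that compound 1 shows the small reading 8.1%, the loss of a methoxy group is expected to leave the reading within the usual scatter rather than move it in either direction. Compound 3 is therefore estimated at 7%, between 1% and 18%, which would mean an expected step of a number 1.1 percentage points lower from compound 1 to compound 3 (within the scatter).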

Compound 3, a percentage reported as activity, at one concentration (the size of the read-out at that concentration, not a potency): 7%
For compound 3 middle estimate and measured number coincide at the digits printed; the measured number falls inside the stated range.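

In this assay, replacing the methoxy group with hydrogen on the six-membered aromatic ring, para to a large group, gives a number 1.1 percentage points lower from compound 1 to compound 3 (within the scatter). This is the only pair shown that differs in one place, and it indicates that, on this core, the reading does not detectably depend on having methoxy rather than hydrogen at this position. Nothing measured here offers an explanation for this result.

Going by these compounds, whether a different group at this position, such as an amine, a carboxylic acid or a longer chain, would also keep the reading within the scatter remains open. Also open, on these data alone, is whether the same swap would behave alike on a different core, such as that of compound 2, which has no numerical reading.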